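A sulfonamide swap: hydroxyethyl out, phenyl in

The source may report more compounds than this note shows. Statements on the series, on what has been measured and on what is new or still open speak of the compounds shown alone.

Compound 1, `CC[C@@H]1C(=O)N(C)c2cnc(Nc3ccc(S(=O)(=O)NCCO)cc3)nc2N1C1CCCC1`, is the starting point of this comparison. Among the compounds with values here, in a functional assay on A549 cells (Homo sapiens) for antiproliferative activity, read by CCK-8 assay, with a stated time of 72 h (on this read-out higher numbers stand for weaker inhibition of growth and lower numbers for stronger inhibition of growth), compound 1 gives 563 nM, the lowest of the three numbers measured so far. The other two compounds share the core but carry different groups on it: compound 2, `CCC1C(=O)N(C)c2cnc(-n3ccc4cc(C(=O)NC5CCCC5)ccc43)nc2N1c1ccn(C)n1`, gives 39500 nM, and compound 3, `CCNC(=O)c1ccc2c(ccn2-c2ncc3c(n2)N(c2ccn(C)n2)C(CC)C(=O)N3C)c1`, gives 21700 nM. Within the data shown here, the one single-point step among the measured compounds, a 1.8-fold lower number from compound 2 to compound 3 (0.26 log units; within the scatter), concerns the group on an amide-type nitrogen and stays within the usual scatter.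

Compound 4, `CC[C@@H]1C(=O)N(C)c2cnc(Nc3ccc(S(=O)(=O)Nc4ccccc4)cc3)nc2N1C1CCCC1`, differs from compound 1 in one place: phenyl in place of 2-hydroxyethyl on a sulfonamide nitrogen. Among the measured compounds shown here, no measured step touches this sulfonamide nitrogen, so nothing measured speaks directly to the change. For the measured compounds named here, the only comparison available, the step from compound 2 to compound 3, sits elsewhere on the molecule and did not move beyond the scatter, which offers no reason to expect a large shift here either. The estimate for compound 4 is therefore a 1.1-fold higher number from compound 1 to compound 4 (0.03 log units; within the scatter), a step not expected to exceed the scatter. Compound 4 is expected to give about 600 nM in this assay, with a plausible range from 150 nM to 2500 nM.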

Compound 4, concentration for 50% growth inhibition: 4150 nM
Beside the measured number, compound 4's estimate is 6.9-fold (0.84 log units) below it; the measured number lies above the stated range.
By their numbers in this assay, from the lowest: compound 1; then compound 4; then compounds 3 and 2 (each within the scatter of the next).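

Within the data shown here, the sulfonamide nitrogen proves to be a position where the choice of group matters: in this assay, phenyl in place of 2-hydroxyethyl gives a 7.4-fold higher number from compound 1 to compound 4 (0.87 log units; beyond the scatter) and so weakens growth inhibition, whereas the only earlier single-place step, on an amide-type nitrogen, stayed within the scatter. This swap changes several things at once, as the 2-hydroxyethyl that leaves has 3 heavy atoms, no ring, 1 hydrogen-bond donor and 1 hydrogen-bond acceptor, while the phenyl that enters has 6 heavy atoms, an aromatic ring and neither donor nor acceptor. Nothing available here explains why this swap raises the number.

A single swap cannot show which of those differences counts, and a 2-methoxyethyl group, which keeps the chain but replaces the hydroxyl with a methyl ether, or a cyclohexyl group, which keeps a six-membered ring but is not aromatic, would help to separate them. Going by these compounds, it also remains open whether a 2-aminoethyl group, a carboxylic acid on the chain or a longer 3-hydroxypropyl chain would stay close to compound 1 or move further from it.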